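Solubility in a squaric-acid-derived hydroxamate series

The source may hold more compounds than are shown below. What is called first, only, known or untested is meant among the compounds shown, and "the series" means these compounds.

Three compounds share one core. Compound 1 `O=C(CCCCCCNc1c(Nc2ccccc2)c(=O)c1=O)NO` and compound 2 `O=C(CCCCCNc1c(Nc2ccccc2)c(=O)c1=O)NO` have been measured; compound 3 `C[C@@H](Nc1c(NCCCCCC(=O)NO)c(=O)c1=O)c1ccccc1` has not. In a physicochemical assay for solubility, read by HPLC, in phosphate buffer, with a stated time of 24 h, at pH 7.4, tested at 100 uM (on this read-out lower numbers stand for lower solubility and higher numbers for higher solubility), compound 1 gives 6000000 nM, and compound 2 gives 47000000 nM, the higher of the two numbers. Among the compounds with values here, the only measured step, a 7.8-fold higher number from compound 1 to compound 2 (0.89 log units; beyond the scatter), concerns the chain carrying the hydroxycarbamoyl group and not the aryl substituent on the ring nitrogen. Compound 3 differs from compound 2 by 1-phenylethyl in place of phenyl on a nitrogen on an aromatic ring. Within the data shown here, no measured step bears on this change, so the expectation rests on the size of the added group alone. The step is expected to be a modest fall, a 3.1-fold lower number from compound 2 to compound 3 (0.50 log units; beyond the scatter), within or just beyond the scatter. Compound 3 is therefore expected to give about 15000000 nM in this assay, with a plausible range from 4000000 nM to 50000000 nM.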

Compound 3, solubility: 80000000 nM
Compound 3: the middle estimate sits 5.3-fold (0.73 log units) below what was measured; measured number outside the range, above it.
By their numbers in this assay, from the lowest: compound 1; then compounds 2 and 3 (each within the scatter of the next).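

The change on this nitrogen on an aromatic ring, 1-phenylethyl in place of phenyl, adds carbon and a defined stereocentre, yet in this assay it gives a 1.7-fold higher number from compound 2 to compound 3 (0.23 log units; within the scatter). Within the data shown here, this is the first reading at this position, and here the size of the added group did not separate the two compounds, whereas the chain step, a 7.8-fold higher number from compound 1 to compound 2 (0.89 log units; beyond the scatter), lies beyond the scatter. Nothing given here accounts for this result.

Open, on these data alone, is whether the mirror-image 1-phenylethyl group, a benzyl group or a phenyl ring carrying an amine or a carboxylic acid would also stay within the scatter of compound 2. Also open, as far as these compounds go, is whether 1-phenylethyl would behave the same way on the longer chain of compound 1.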